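The compounds below may be only part of what the source reports. "The series", "measured", "known", "first", "only" and "open" are said of these compounds alone.

Compound 1 `CC(C)=CC(=O)Nc1cc2c(N3CCc4ccccc43)ncnc2cc1O[C@@H]1CCOC1` shows the lowest of the two numbers in a functional assay on PC-3 cells (Homo sapiens) for antiproliferative activity, read by MTT assay, with a stated time of 72 h (on this read-out lower numbers stand for stronger inhibition and higher numbers for weaker inhibition), giving 4620 nM; compound 2 `CCC/C=C/C(=O)Nc1cc2c(N3CCc4ccccc43)ncnc2cc1O[C@@H]1CCOC1` gives 9230 nM, and a 2.0-fold higher number from compound 1 to compound 2 (0.30 log units; within the scatter) stays within the scatter. Compound 3 `CC(C)=CC(=O)Nc1cc2c(N3CCCc4ccccc43)ncnc2cc1O[C@@H]1CCOC1` differs from compound 1 by 1,2,3,4-tetrahydroquinolin-1-yl in place of 2,3-dihydro-1H-indol-1-yl on an aromatic carbon. For the measured compounds named here, the one measured step alters the group on the carbonyl carbon, not the group on the aromatic carbon, so no measured step bears on this change. Compound 3 is therefore expected to sit close to the number of compound 1. The step of a 1.1-fold higher number from compound 1 to compound 3 (0.03 log units; within the scatter) is expected not to exceed the scatter, and compound 3 is estimated at 5000 nM, within 1500 nM to 16000 nM.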

Compound 3, half-maximal inhibitory concentration: 9020 nM
Estimate against measurement, compound 3: 1.8-fold (0.26 log units) below; the measured number falls inside the stated range.
By their numbers in this assay, from the lowest: compounds 1, 3 and 2 (each within the scatter of the next).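

Replacing 2,3-dihydro-1H-indol-1-yl with 1,2,3,4-tetrahydroquinolin-1-yl on this aromatic carbon gives a 2.0-fold higher number from compound 1 to compound 3 (0.29 log units; within the scatter) in this assay and so stays within the scatter. For the compounds shown here, this position, which no earlier step touched, therefore takes a six-membered non-aromatic ring in place of a five-membered one without a change beyond the scatter. Nothing available accounts for this result. Open questions remain about how a morpholine or an open-chain amine on this aromatic carbon would read, and whether 1,2,3,4-tetrahydroquinolin-1-yl would behave the same with pent-1-en-1-yl on the carbonyl carbon.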